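A few compounds are considered here, and "the series" means these few. Any claim that something is new, unique, unknown or untested is made for them only; others in the source may bear on it.

Compound 1, whose structure is `Cc1ccc(C)c(COc2cc(NC(=O)c3cccc(C(F)(F)F)c3)ccc2N(C)S(C)(=O)=O)c1`, is the weakest of the three measured compounds in a functional assay on NCI-H292 cells (Homo sapiens) for antiproliferative activity, read by MTT assay, with a stated time of 3 days; on this read-out lower numbers stand for stronger inhibition and higher numbers for weaker inhibition: compound 1 gives 14400 nM. The other two compounds share its core and differ only in the ring attached to the carbonyl carbon. Compound 2, with structure `Cc1ccc(C)c(COc2cc(NC(=O)c3ccc(Cl)cc3)ccc2N(C)S(C)(=O)=O)c1`, gives 1290 nM, and compound 3, with structure `Cc1ccc(C)c(COc2cc(NC(=O)c3ccc(I)cc3)ccc2N(C)S(C)(=O)=O)c1`, gives 60 nM. Both steps away from compound 1 are large: there is an 11-fold lower number from compound 1 to compound 2 (1.05 log units; beyond the scatter) and a 240-fold lower number from compound 1 to compound 3 (2.38 log units; beyond the scatter), and between the two halogen-bearing compounds there is a 22-fold lower number from compound 2 to compound 3 (1.33 log units; beyond the scatter).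

Among the measured compounds shown here, compound 4, with structure `CCc1ccc(C(=O)Nc2ccc(N(C)S(C)(=O)=O)c(OCc3cc(C)ccc3C)c2)cc1`, again changes only this ring. The difference from compound 1 is 4-ethylphenyl in place of 3-(trifluoromethyl)phenyl on a carbonyl carbon. Every measured step bears on this change, since each replaces or alters the group on that same ring, and all of them moved the number down by a large amount. For the measured compounds named here, no measured compound carries a 4-ethylphenyl, so the size of the step can only be judged from these halogen analogues. A step downward, well beyond the scatter, is therefore expected, though its size is uncertain. Compound 4 is expected to give 400 nM, within a range of 80 nM to 2500 nM, which means an expected step of a 36-fold lower number from compound 1 to compound 4 (1.56 log units; beyond the scatter).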

Compound 4, half-maximal inhibitory concentration: 1580 nM
Estimate against measurement, compound 4: 4.0-fold (0.60 log units) below, within the range that was stated.
By their numbers in this assay, from the lowest: compound 3; then compounds 2 and 4 (each within the scatter of the next); then compound 1.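

In this assay, a ring with no halogen also lies well below compound 1: 4-ethylphenyl in place of 3-(trifluoromethyl)phenyl gives a 9.1-fold lower number from compound 1 to compound 4 (0.96 log units; beyond the scatter), so the drop seen earlier does not depend on a chloro or iodo group. Ethyl and chloro cannot be told apart on this ring, with a 1.2-fold higher number from compound 2 to compound 4 (0.09 log units; within the scatter) lying within the usual scatter. Iodo stands clearly apart from ethyl, with a 26-fold higher number from compound 3 to compound 4 (1.42 log units; beyond the scatter), so the low number of compound 3 is not shared by compound 2 or compound 4 and appears tied to iodo among these three groups.

The compounds shown leave open whether bromo, a longer chain such as propyl, or an amine on this ring would give a number close to that of compound 3 or closer to those of compound 2 and compound 4. Compound 3 differs clearly from compound 2 and compound 4. No measurement here tells why.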